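Shifting One Hydroxyl: From Compound 3 to Compound 4

The compounds below may be only part of what the source reports. "The series", "measured", "known", "first", "only" and "open" are said of these compounds alone.

Compound 1 `CN1C(=S)N(C2CCCCC2)C(=O)/C1=C/c1ccc(O)cc1O`: 26000 nM
Compound 2 `CN1C(=S)N(C2CCCCC2)C(=O)/C1=C/c1ccc(N(C)C)cc1`: 12300 nM
Compound 3 `CN1C(=S)N(c2ccc3c(c2)CCC3)C(=O)/C1=C/c1ccc(O)cc1O`: 6580 nM

In an assay for inhibition of NADPH oxidase 1 (Homo sapiens), read by chemiluminescence (on this read-out lower numbers stand for stronger inhibition and higher numbers for weaker inhibition), compound 3 gives the lowest of the three numbers. Compound 2 stands within the scatter of compound 3, while compound 1 lies beyond it. Compound 4 `CN1C(=S)N(c2ccc3c(c2)CCC3)C(=O)/C1=C/c1cccc(O)c1O` differs from compound 3 in one place: 2,3-dihydroxyphenyl in place of 2,4-dihydroxyphenyl on a double-bonded chain carbon bound to a double-bonded ring carbon. Within the data shown here, none of the measured compounds isolates such a shift of a hydroxyl, so the measured numbers give no direction for it. The step from compound 3 to compound 4 is expected to stay within the scatter, at a 1.0-fold lower number from compound 3 to compound 4 (0.01 log units; within the scatter). Compound 4 is accordingly estimated at 6500 nM, with a range from 2200 nM to 20000 nM.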

Compound 4, inhibition constant: 6630 nM
The estimate for compound 4 lay 1.0-fold (0.01 log units) below the measured number; the range from low to high includes it.
By their numbers in this assay, from the lowest: compounds 3, 4 and 2 (each within the scatter of the next); then compound 1.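

In this assay, 2,3-dihydroxyphenyl in place of 2,4-dihydroxyphenyl on a double-bonded chain carbon bound to a double-bonded ring carbon gives a 1.0-fold higher number from compound 3 to compound 4 (0.00 log units; within the scatter) and so stays within the scatter. Among these compounds, this is the first pair to isolate such a shift of a hydroxyl, and at this place the read-out does not separate the two arrangements. Nothing measured here bears on why the two compounds read alike.

From the compounds shown here alone, whether a methoxy group or an amine on that phenyl ring would read alike remains open. So does whether the same shift reads alike on the core of compound 1 .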